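Halogen exchange on an indole scaffold against calpain-1

A few compounds are considered here, and "the series" means these few. Any claim that something is new, unique, unknown or untested is made for them only; others in the source may bear on it.

Three analogues have been measured in an assay on isolated protein for inhibition of Calpain-1 catalytic subunit (Sus scrofa), read by FRET; a higher number here means a weaker inhibitor, a lower number a stronger inhibitor. Compound 1, `O=C(O)/C(S)=C/c1c[nH]c2ccc(I)cc12`, gives 100 nM. Compound 2, `O=C(O)/C(S)=C/c1c[nH]c2ccc(Br)cc12`, gives 6 nM. Compound 3, `O=C(O)/C(S)=C/c1c[nH]c2c(I)cccc12`, gives 90 nM. Compound 2 differs from compound 1 by bromo in place of iodo on an aromatic carbon, and this change produced a 17-fold lower number from compound 1 to compound 2 (1.22 log units; beyond the scatter). Compound 3 and compound 1 have the same atoms joined differently; the difference between the two cores is not broken down here. Compound 3 and compound 1 give values within the scatter of each other, while compound 2 stands well apart from both.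

Compound 4, `O=C(O)/C(S)=C/c1c[nH]c2c(Br)cccc12`, has not yet been measured in this assay. It differs from compound 3 by bromo in place of iodo on an aromatic carbon. This is the same kind of change as that from compound 1 to compound 2, though the surroundings differ: in compound 1 the halogen sits meta to a fused ring and para to a fused ring, whereas in compound 3 it sits ortho to a fused ring and meta to a fused ring. Among the measured compounds shown here, because a 17-fold lower number from compound 1 to compound 2 (1.22 log units; beyond the scatter) was large, a similar direction is expected for compound 4, with a 7.5-fold lower number from compound 3 to compound 4 (0.88 log units; beyond the scatter) estimated, tempered by the single precedent and the changed position. Compound 4 is thus expected to give 12 nM, likely between 4 nM and 45 nM.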

Compound 4, half-maximal inhibitory concentration: 2 nM
Compound 4: middle estimate off by 6.0-fold (0.78 log units), on the high side; measured number below the stated range.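

In this assay, bromo in place of iodo on an aromatic carbon again gave a lower number, with a 45-fold lower number from compound 3 to compound 4 (1.65 log units; beyond the scatter), so the direction of the change carried over from one core to the other. The size of the step did not carry over unchanged, and the gap between the two steps is larger than repeated measurements would account for: the same change on two cores in this assay, a 17-fold lower number (1.22 log units; beyond the scatter) from compound 1 to compound 2 and a 45-fold lower number (1.65 log units; beyond the scatter) from compound 3 to compound 4, 2.7-fold (0.43 log units) apart, beyond the scatter of two such steps. Among the compounds shown here, with only two matched pairs, this shows that the direction held on both cores, but it does not show why the step is larger on the core of compound 3, nor how large it would be on any further core.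

The compounds shown carry only iodo and bromo on the six-membered ring, so they leave open how chloro, fluoro, methoxy or a nitrile at the same places would read in this assay. They also leave open whether the halogen exchange would give a similar step with an ester or an amide in place of the carboxylic acid.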